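A Fluorine Added to the Benzamide of Compound 2

A few compounds are considered here, and "the series" means these few. Any claim that something is new, unique, unknown or untested is made for them only; others in the source may bear on it.

Of the compounds shown here, two have been measured for how strongly they slow the growth of ovarian carcinoma cells. Compound 1 `COc1cccc(-c2nn(-c3ccccc3)cc2-c2ccnc(NCCCNC(=O)Nc3ccc(Cl)c(Cl)c3)c2)c1` carries a urea at the end of its three-carbon chain, and in a functional assay on cells (Panel ovarian (Carcinoma cell lines), Homo sapiens) for antiproliferative activity (on this read-out higher numbers stand for weaker inhibition of growth and lower numbers for stronger inhibition of growth), compound 1 gives 3740 nM. Compound 2 `O=C(NCCCNc1cc(-c2cn(-c3ccccc3)nc2-c2cccc(O)c2)ccn1)c1ccccc1` instead ends that chain in a benzamide, and in this assay compound 2 gives 4170 nM. The two numbers lie within the usual scatter of each other, so neither compound can be set apart from the other on this read-out.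

Compound 3 `O=C(NCCCNc1cc(-c2cn(-c3ccccc3)nc2-c2cccc(O)c2)ccn1)c1ccc(F)cc1` differs from compound 2 in one place: fluoro in place of hydrogen on an aromatic carbon. For the measured compounds named here, no measured pair shows what such a change does here, and a single fluorine added to a ring at the far end of the molecule is the kind of change that usually moves a number little. The step from compound 2 to compound 3 is therefore expected to be small, in no particular direction, and to stay within the scatter: a 1.1-fold lower number from compound 2 to compound 3 (0.05 log units; within the scatter). Compound 3 is expected to give about 3700 nM, in a range from 1500 nM to 9000 nM.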

Compound 3, concentration for 50% growth inhibition: 3460 nM
For compound 3 the middle estimate is 1.1-fold (0.03 log units) above the measured one; low and high end bracket the measured number.
By their numbers in this assay, from the lowest: compounds 3, 1 and 2 (each within the scatter of the next).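

In this assay, putting fluoro in place of hydrogen, para to a large group on the benzamide's six-membered ring, gives a 1.2-fold lower number from compound 2 to compound 3 (0.08 log units; within the scatter). For the compounds shown here, this is the first pair here that differs in only one place, and it shows that this ring carbon can carry a fluorine with no step that stands out from the scatter, although one pair in one assay cannot show how the change behaves on other compounds. Nothing available here offers an explanation for this result.

Still open, as far as these compounds go, is whether a chlorine, a methoxy group, an amine or a carboxylic acid on the same carbon would also stay within the scatter. Also open, from the compounds shown here alone, is whether a fluorine on another carbon of this ring would give a step beyond the scatter.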